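This account rests on a few compounds, and the source may have more. Where it says the series, first, only, none or still open, it means among the compounds named here.

Measured so far in a functional assay on HCT-116 cells (Homo sapiens) for cytotoxicity, read by MTT assay, with a stated time of 72 h; a lower number here means a stronger inhibitor, a higher number a weaker inhibitor:

compound 1 `C[C@@H](Nc1c(C(=O)NCc2ccc(F)cc2)nc(Br)c2cccnc12)c1ccccc1` — > 20000 nM
compound 2 `CS(=O)(=O)NCCCN(c1nc(C(=O)NCc2ccc(F)cc2)c(O)c2ncccc12)S(C)(=O)=O` — 7000 nM
compound 3 `O=C(NCc1ccc(F)cc1)c1nc(NCCO)c2cccnc2c1O` — "not determined" (no result reported)

Compound 1 stands at the edge of what this assay can report: its entry of > 20000 nM is a limit, not a number, and nothing more precise is known about it. Compound 2, built on a different pattern of substituents, does give a number, 7000 nM. For compound 3 no result was reported in this assay. No pair of these compounds differs in only one place, so no measured step can be read off among them.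

The next compound, compound 4 `CN(C)CCCNc1c(C(=O)NCc2ccc(F)cc2)nc(Br)c2cccnc12`, keeps the core of compound 1 and changes one group: 3-(dimethylamino)propyl in place of 1-phenylethyl on a nitrogen on an aromatic ring. Because compound 1 sits at the limit of > 20000 nM in this assay, at which 1 of the 3 values shown sits, the step to compound 4 can only be judged downward from that edge or not at all. The expectation is a step of an at least 1.3-fold lower number from compound 1 to compound 4 (0.12 log units; that floor lies within the scatter), with a fair chance that compound 4 again returns only a limit. Compound 4 is estimated at 15000 nM, within a range from 4000 nM to 40000 nM.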

Compound 4, half-maximal inhibitory concentration: > 10000 nM
Compound 4 gave a limit, no number; the forecaster's own chance of this, stated with the estimate: 50%; the middle value lies beyond the limit too.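

Within the data shown here, compound 1 and compound 4 each returned only a limit, not a number, and no step between them can be read. The compounds shown leave open whether 3-(dimethylamino)propyl in place of 1-phenylethyl on that nitrogen changes cytotoxicity at all, and in which direction.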